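Swapping Two Ester Arms on a Triazole Side Chain

The source may report more compounds than this note shows. Statements on the series, on what has been measured and on what is new or still open speak of the compounds shown alone.

Measured compounds:
- compound 1, `C#Cc1cccc(NC(=O)c2cn(CC(=O)OCC)nn2)c1`: 91000 nM
- compound 2, `C#Cc1cccc(NC(=O)c2cn(CCOC(C)=O)nn2)c1`: 25100 nM
- compound 3, `CCOC(=O)Cn1cc(CNC(=O)c2cn(CC(=O)OCc3ccccc3)nn2)nn1`: > 100000 nM

All three were tested in a functional assay on B16 cells (Mus musculus) for cytotoxicity, read by MTT assay, with a stated time of 48 h; a lower number here means a stronger inhibitor, a higher number a weaker inhibitor. Compound 1 and compound 2 share one core and differ in a single place, (acetoxymethyl in place of ethoxycarbonyl on a saturated chain carbon bound to an aromatic nitrogen). That change gave a 3.6-fold lower number from compound 1 to compound 2 (0.56 log units; beyond the scatter), a shift that is larger than the usual scatter of repeated measurements. Compound 3 reaches only a limit in this assay, > 100000 nM, so no number is known for it; of the three values shown, (the limit of > 100000 nM in this assay, at which 1 of the 3 values shown sits). How the core of compound 3 differs from the core of compound 1 is not broken down here.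

Compound 4, `CC(=O)OCCn1cc(CNC(=O)c2cn(CC(=O)OCc3ccccc3)nn2)nn1`, has not yet been measured. It relates to compound 3 exactly as compound 2 relates to compound 1: the difference is acetoxymethyl in place of ethoxycarbonyl on a saturated chain carbon bound to an aromatic nitrogen, and the place is described in the same words for both pairs, so it is the same change on a different core.

For compound 4 the expected value in this assay is 100000 nM, with a likely range from 30000 nM to 300000 nM. The expected step of a number no higher from compound 3 to compound 4 (the limit leaves the size open) rests on the earlier step of a 3.6-fold lower number from compound 1 to compound 2 (0.56 log units; beyond the scatter) and on the fact that compound 3 is known only as a limit, which leaves it uncertain whether compound 4 will yield a number at all.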

Compound 4, half-maximal inhibitory concentration: > 100000 nM
Compound 4: no number, only a limit; the forecaster's own chance of this, stated with the estimate: 50%; the middle value sits exactly at the limit.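

Compound 4 gives only a limit in this assay, > 100000 nM, and not a number. Among the compounds shown here, compound 3 gives only a limit there too, so no step from compound 3 to compound 4 can be read. The compounds shown leave open whether acetoxymethyl in place of ethoxycarbonyl changes anything on the core of compound 3, as it did on the core of compound 1, because both compounds stop at the same limit: the limit of > 100000 nM in this assay, at which 2 of the 4 values shown sit.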